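Side-chain urea in place of the piperidinyl ester

The source may report more compounds than this note shows. Statements on the series, on what has been measured and on what is new or still open speak of the compounds shown alone.

For the measured compounds named here, compound 1 `COC(=O)CC1CCN(C[C@H]2CN(c3ccc(-n4cc(-c5ccccn5)cn4)c(F)c3)C(=O)O2)CC1` stands lowest of the three measured members: in a physicochemical assay for lipophilicity, read by HPLC, measured as octanol-water partition (a lower number here means a more polar compound, a higher number a more lipophilic compound), compound 1 gives 1.78. Compound 2 `CC(=O)OC[C@H]1CN(c2ccc(-n3cc(-c4ccccn4)cn3)c(F)c2)C(=O)O1` gives 2.09 in this assay, and compound 3 `O=C1O[C@@H](CSc2cccs2)CN1c1ccc(-n2cc(-c3ccccn3)cn2)c(F)c1` gives 4.29. Both steps away from compound 1 run upward, though very unequally: a number 0.31 log units higher from compound 1 to compound 2 (beyond the scatter), whereas a number 2.51 log units higher from compound 1 to compound 3 (beyond the scatter). Between the other two, a number 2.20 log units higher from compound 2 to compound 3 (beyond the scatter).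

Compound 4 `CCNC(=O)NC[C@H]1CN(c2ccc(-n3cc(-c4ccccn4)cn3)c(F)c2)C(=O)O1` has not yet been measured. Its change from compound 1 is (ethylcarbamoyl)amino in place of 4-((methoxycarbonyl)methyl)piperidin-1-yl on a saturated chain carbon bound to a saturated ring carbon. Going by the values given here, of the measured steps, the nearest precedent is a number 0.31 log units higher from compound 1 to compound 2 (beyond the scatter), where a smaller group with fewer heavy atoms likewise replaced the piperidinyl ester on the same saturated chain carbon. The step to compound 3 is of a different kind, a thiophenyl sulfide, and does not bear directly on a urea. Given a number 0.31 log units higher from compound 1 to compound 2 (beyond the scatter), and the two hydrogen-bond donors counted for the entering (ethylcarbamoyl)amino against none for acetoxy, the expected step is small and within the usual scatter: a number 0.02 log units higher from compound 1 to compound 4 (within the scatter). Compound 4 is therefore estimated at 1.8 in this assay, with a range from 1.3 to 2.3.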

Compound 4, partition coefficient: 2.45
Compound 4: middle estimate off by 0.65 log units, on the low side; measured number above the stated range.
By their numbers in this assay, from the lowest: compound 1; then compound 2; then compound 4; then compound 3.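

In this assay the urea side chain does not fall to the low end of the series: the data show a number 0.36 log units higher from compound 2 to compound 4 (beyond the scatter) and a number 0.67 log units higher from compound 1 to compound 4 (beyond the scatter) on the saturated chain carbon bound to a saturated ring carbon, so the hydrogen-bond donors of (ethylcarbamoyl)amino, absent from both groups it is compared with here, do not come with a lower number at this position. The (thiophen-2-yl)sulfanyl group remains far apart, with a number 1.84 log units lower from compound 3 to compound 4 (beyond the scatter) at the same place, so compound 4 lies in the lower part of the span yet clear of both compound 1 and compound 2. Nothing available accounts for this order.

The compounds shown hold a single urea, so whether the rise belongs to the urea as a whole or to its ethyl group stays open, and a methylurea or a urea with a longer chain would separate the two. A primary amine or a carboxylic acid on the same chain carbon would show how low the numbers at this position can go.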